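A few compounds are considered here, and "the series" means these few. Any claim that something is new, unique, unknown or untested is made for them only; others in the source may bear on it.

Of the compounds shown here, two have been measured so far in an ADME assay on TZM cells (Homo sapiens) for cytotoxicity, read by WST assay, with a stated time of 2 days; on this read-out higher numbers stand for lower toxicity in this test and lower numbers for higher toxicity in this test. Compound 1 (`COc1ccc(CN(C)c2nc(Cc3c(Cl)cccc3Cl)c(C)c(=O)[nH]2)cc1`) gives 17900 nM in this test. Compound 2 (`Cc1c(C(C)c2c(Cl)cccc2Cl)nc(N(C)Cc2ccc(N3CCN(C)CC3)cc2)[nH]c1=O`) gives > 10000 nM as its result. That result is a limit and not a number, so compound 2 has no exact place on the scale. Compound 3 (`COc1ccc(CN(C)c2nc(C(C)c3c(Cl)cccc3Cl)c(C)c(=O)[nH]2)cc1`) differs from compound 2 in one place: methoxy in place of 4-methylpiperazin-1-yl on an aromatic carbon. Among the compounds with values here, no measured pair shows what this swap does, so any forecast is rough. Compound 1 also carries methoxy and sits at 17900 nM in this assay as the only exact figure available. The expected step that the limit leaves unreadable from compound 2 to compound 3 is therefore none beyond the scatter, with no clear direction. For compound 3 the estimated value is 18000 nM within an expected range of 7000 nM to 50000 nM in this assay as well.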

Compound 3, half-maximal cytotoxic concentration: > 100000 nM
Compound 3 was reported as a limit; the forecaster's own chance of this, stated with the estimate: 30%; middle value at least 5.5-fold (0.74 log units) away from the limit.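

In this assay, within the data shown here, methyl in place of hydrogen on the saturated chain carbon bound to two aromatic carbons gives an at least 5.5-fold higher number from compound 1 to compound 3 (0.74 log units; beyond the scatter), so at this position the added methyl goes with lower toxicity in this test, something no earlier pair could show. From the compounds shown here alone, compound 3 gives > 100000 nM, which is a limit of the assay and not a number, so the full size of this step is unknown. The results for compound 2 and compound 3 are both limits, and the step between them cannot be read, so the swap of 4-methylpiperazin-1-yl for methoxy still has no measured size.

This methyl effect rests on a single pair of compounds. Going by these compounds, it remains open whether an ethyl or a hydroxyl on the same chain carbon would go the same way, and whether a simple amine such as dimethylamino in place of methoxy would keep the number this high.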